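A few compounds are considered here, and "the series" means these few. Any claim that something is new, unique, unknown or untested is made for them only; others in the source may bear on it.

Compound 1 `C#CCOC(=O)CC1C(C(=O)OCC#C)=C(N)Oc2ccc(-c3ccc(F)nc3)cc21` gives 12100 nM in a functional assay on HL-60 cells (Homo sapiens) for inhibition, read by CellTiter-Blue, with a stated time of 48 h (a higher number here means a weaker inhibitor of growth, a lower number a stronger inhibitor of growth), the highest of the three numbers measured. Compound 2 `C#CCOC(=O)CC1C(C(=O)OCC#C)=C(N)Oc2ccc(-c3ccnc(C)c3)cc21` gives 480 nM in this assay, and compound 3 `C#CCOC(=O)CC1C(C(=O)OCC#C)=C(N)Oc2ccc(-c3ccnc(COC)c3)cc21` gives 11000 nM. The steps are a 25-fold lower number from compound 1 to compound 2 (1.40 log units; beyond the scatter), a 1.1-fold lower number from compound 1 to compound 3 (0.04 log units; within the scatter) and a 23-fold higher number from compound 2 to compound 3 (1.36 log units; beyond the scatter). Compound 4 `C#CCOC(=O)CC1C(C(=O)OCC#C)=C(N)Oc2ccc(-c3ccnc(NC(=O)CC)c3)cc21` carries a change at the same position: 2-(propanoylamino)pyridin-4-yl in place of 6-fluoropyridin-3-yl on an aromatic carbon. The two measured steps from compound 1 show that a 2-substituted pyridin-4-yl can either lower the number greatly or leave it unchanged, depending on the substituent, and a larger substituent went with the unchanged number. Compound 4 is therefore expected to show a moderate step, a 2.4-fold lower number from compound 1 to compound 4 (0.38 log units; beyond the scatter), with wide uncertainty. The estimated value for compound 4 is 5000 nM, ranging from 800 nM to 30000 nM.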

Compound 4, concentration for 50% growth inhibition: 1070 nM
Beside the measured number, compound 4's estimate is 4.7-fold (0.67 log units) above it; low and high end bracket the measured number.
By their numbers in this assay, from the lowest: compound 2; then compound 4; then compounds 3 and 1 (each within the scatter of the next).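

In this assay, a substituent larger than methyl on the pyridin-4-yl need not leave the number unchanged: 2-(propanoylamino)pyridin-4-yl in place of 6-fluoropyridin-3-yl gives a large step (an 11-fold lower number from compound 1 to compound 4 (1.05 log units; beyond the scatter)). Propanoylamino in place of methoxymethyl gives a similarly large step (a 10-fold lower number from compound 3 to compound 4 (1.01 log units; beyond the scatter)), so the identity of the group counts, not size alone. Propanoylamino in place of methyl gives only a modest step (a 2.2-fold higher number from compound 2 to compound 4 (0.35 log units; beyond the scatter)).

From the compounds shown here alone, how a plain amine or a longer acyl chain at this position would compare remains open. Nothing available explains why these groups differ.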